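Phenyl replaces the anilino arm at the assay limit

A few compounds are considered here, and "the series" means these few. Any claim that something is new, unique, unknown or untested is made for them only; others in the source may bear on it.

In a functional assay on NALM-6 cells (Homo sapiens) for cytotoxicity, with a stated time of 72 h (a higher number here means that more compound is needed for the effect, a lower number that less compound is needed), compound 1 (`C=C[C@@](C)(/C=C/c1ccc(Nc2ccc(OC)cc2)cc1)CCC=C(C)C`) gives > 43400 nM as a limit and not as a number. Compound 2 (`C=C[C@@](C)(/C=C/c1ccc(Nc2cc(F)cc(F)c2)cc1)CCC=C(C)C`) gives > 43400 nM as a limit too, so its standing is known only in that form. The two compounds share one mark (the limit of > 43400 nM in this assay, at which 2 of the 2 values shown sit) and neither has a readable number.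

Compound 3 (`C=C[C@@](C)(/C=C/c1ccc(-c2ccccc2)cc1)CCC=C(C)C`) differs from compound 2 by one change (phenyl in place of (3,5-difluorophenyl)amino on an aromatic carbon) with phenyl in place of (3,5-difluorophenyl)amino on an aromatic carbon. For the measured compounds named here, the only measured step that bears on this is a step that the two limits leave unreadable from compound 1 to compound 2 and it offers no size to carry forward. Going by the values given here, it also keeps the nitrogen that compound 3 gives up, so the new change has no measured precedent. No step beyond the scatter is therefore expected in this assay and no direction can be argued. The expected change is an at least 1.0-fold lower number from compound 2 to compound 3 (0.03 log units; that floor lies within the scatter) as an estimate with little behind it. Compound 3 may well return a limit as well. For compound 3 the estimated value is 40000 nM with an expected range from 15000 nM to 60000 nM in this reading.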

Compound 3, half-maximal effective concentration: > 43400 nM
Compound 3: only a limit was reported; the forecaster's own chance of this, stated with the estimate: 65%; middle value at least 1.0-fold (0.03 log units) from the limit.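

In this assay compound 3 gives > 43400 nM as a limit and not as a number. No step among compound 1, compound 2 and compound 3 can therefore be read, since all three carry the same mark: the limit of > 43400 nM in this assay, at which 3 of the 3 values shown sit.

The compounds shown leave open whether any of these changes to the shared core alters the number at all, and in which direction.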